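This account rests on a few compounds, and the source may have more. Where it says the series, first, only, none or still open, it means among the compounds named here.

Compound 1 `O=C1/C(=C/c2cccc([N+](=O)[O-])c2)CN(S(=O)(=O)c2ccc(F)cc2)C/C1=C\c1cccc([N+](=O)[O-])c1`: 3980 nM
Compound 2 `COc1cc(/C=C2\CN(S(=O)(=O)c3ccc(F)cc3)C/C(=C\c3cc(OC)cc(OC)c3)C2=O)cc(OC)c1`: 8210 nM

In a functional assay on SMMC-7721 cells (Homo sapiens) for cytotoxicity, read by MTT assay, with a stated time of 24 h (on this read-out lower numbers stand for stronger inhibition and higher numbers for weaker inhibition), compound 1 gives 3980 nM, the lower of the two numbers and so the stronger inhibition. The gap to compound 2 at 8210 nM lies just beyond the usual scatter of repeated measurements.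

Compound 3 `CC(=O)Nc1ccc(S(=O)(=O)N2C/C(=C\c3cccc([N+](=O)[O-])c3)C(=O)/C(=C/c3cccc([N+](=O)[O-])c3)C2)cc1` keeps the core of compound 1 and changes in one place. Acetamido stands in place of fluoro on an aromatic carbon, para to a large group, so that 4-fluorophenyl becomes 4-acetamidophenyl (acetamido in place of fluoro on an aromatic carbon).

Going by the values given here, no pair of measured compounds shows this change, so the data give no direct guide, and any forecast is uncertain. In this assay a small step toward a higher number, probably not beyond the scatter, is expected: a 1.3-fold higher number from compound 1 to compound 3 (0.10 log units; within the scatter). For compound 3 the estimated value is 5000 nM, with an expected range from 1800 nM to 14000 nM.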

Compound 3, half-maximal inhibitory concentration: 8420 nM
The estimate for compound 3 lay 1.7-fold (0.23 log units) below the measured number; the measured number falls inside the stated range.
By their numbers in this assay, from the lowest: compound 1; then compounds 2 and 3 (each within the scatter of the next).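

In this assay the change from 4-fluorophenyl to 4-acetamidophenyl gives a 2.1-fold higher number from compound 1 to compound 3 (0.33 log units; beyond the scatter) and so weakens inhibition by a modest step. Going by these compounds alone, this is the first direct sign that the group on this aromatic carbon, para to a large group, matters in this assay: with the rest of compound 1 unchanged, swapping the single fluoro atom for the larger acetamido costs some inhibition without abolishing it. No measurement at hand explains the step.

Going by these compounds, it remains open whether the loss follows the amide hydrogen, the carbonyl or simply the larger size of acetamido. On these data alone, it is also open how an amine or a carboxylic acid on the same carbon would read, and whether a longer chain on the amide would widen the step.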